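Swapping the benzyl ring substituent in a sulfonyl guanidine series

The source may report more compounds than this note shows. Statements on the series, on what has been measured and on what is new or still open speak of the compounds shown alone.

Compound 1 `Cc1cc(S(=O)(=O)/N=C(\N)N/N=C/C#Cc2ccccc2)c(SCc2ccccc2C)cc1Cl`: 13000 nM in a functional assay on MCF7 cells (Homo sapiens) for antiproliferative activity, read by MTT assay, with a stated time of 72 h; a higher number here means a weaker inhibitor, a lower number a stronger inhibitor
Compound 2 `C/C(C#Cc1ccccc1)=N\N/C(N)=N/S(=O)(=O)c1cc(C)c(Cl)cc1SCc1ccccc1C`: 150000 nM in this assay
Compound 3 `C/C(C#Cc1ccccc1)=N\N/C(N)=N/S(=O)(=O)c1cc(C)c(Cl)cc1SCc1ccc(C)cc1`: 125000 nM in this assay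

Among these three, compound 1 gives the lowest number in this assay, and both of its neighbours lie beyond the scatter: a 12-fold higher number from compound 1 to compound 2 (1.06 log units; beyond the scatter), while compound 3 sits close to compound 2, as a 1.2-fold lower number from compound 2 to compound 3 (0.08 log units; within the scatter) shows. Compound 4 `Cc1cc(S(=O)(=O)/N=C(\N)N/N=C/C#Cc2ccccc2)c(SCc2ccc(Cl)cc2)cc1Cl` differs from compound 1 only in one place: 4-chlorophenyl in place of 2-methylphenyl on a saturated chain carbon bound to a sulfur. Among the compounds with values here, the one measured step at the same place, a 1.2-fold lower number from compound 2 to compound 3 (0.08 log units; within the scatter), stayed within the scatter, so no step beyond the scatter is expected for a 1.2-fold higher number from compound 1 to compound 4 (0.06 log units; within the scatter). Compound 4 is therefore estimated at 15000 nM, within 5000 nM to 45000 nM.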

Compound 4, half-maximal inhibitory concentration: 18000 nM
Compound 4: the middle estimate sits 1.2-fold (0.08 log units) below what was measured; low and high end bracket the measured number.
By their numbers in this assay, from the lowest: compounds 1 and 4 (each within the scatter of the next); then compounds 3 and 2 (each within the scatter of the next).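

In this assay, a change on the saturated chain carbon bound to a sulfur now also stays within the scatter on the core of compound 1, this time with a chlorine on the ring instead of a methyl (a 1.4-fold higher number from compound 1 to compound 4 (0.14 log units; within the scatter)). Both measured swaps at this place have therefore left the number close, in two different pairs of compounds. Nothing measured here explains this. From the compounds shown here alone, whether an amine or a carboxylic acid on this ring, or a longer chain in place of the benzyl group, would also leave the number close stays open.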